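Furan-2-yl in place of thiophen-3-yl on the core

A few compounds are considered here, and "the series" means these few. Any claim that something is new, unique, unknown or untested is made for them only; others in the source may bear on it.

Measured so far in a functional assay on HeLa cells (Homo sapiens) for cytotoxicity, read by ELISA, with a stated time of 2 days; a higher number here means a weaker inhibitor, a lower number a stronger inhibitor
- compound 1 `Oc1cccc(-c2cc(-c3ccccc3)cc(-c3ccccc3)n2)c1` gives 16100 nM
- compound 2 `Oc1cccc(-c2cc(-c3ccccc3)cc(-c3ccsc3)n2)c1` gives 13800 nM

Compound 2, at 13800 nM, lies within the scatter of compound 1, so the two numbers cannot be ranked. Both sit at the same level in this assay.

The next compound is compound 3 `Oc1cccc(-c2cc(-c3ccccc3)cc(-c3ccco3)n2)c1`. It carries furan-2-yl in place of thiophen-3-yl on an aromatic carbon, next to the ring nitrogen, and the rest of the structure is unchanged: furan-2-yl in place of thiophen-3-yl on an aromatic carbon.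

Among the measured compounds shown here, only one measured step bears on this change, and it involves the same substituent: a 1.2-fold lower number from compound 1 to compound 2 (0.07 log units; within the scatter). Swapping that group for thiophen-3-yl therefore left the number within the scatter. For the measured compounds named here, a single step is thin evidence, and no furan-2-yl compound has been measured yet. Even so, no shift beyond the scatter is expected, and no direction is favoured. The expected change is estimated as a 1.1-fold lower number from compound 2 to compound 3 (0.03 log units; within the scatter). Compound 3 is estimated at 13000 nM, with an expected range of 6500 nM to 26000 nM.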

Compound 3, half-maximal inhibitory concentration: 9430 nM
Compound 3: middle estimate off by 1.4-fold (0.14 log units), on the high side; measured number inside the range.
By their numbers in this assay, from the lowest: compounds 3, 2 and 1 (each within the scatter of the next).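

With furan-2-yl, the position on the aromatic carbon next to the ring nitrogen has now been read with three different groups in this assay, and the exchange of sulfur for oxygen, together with the change in attachment point from thiophen-3-yl to furan-2-yl, still gives a step inside the scatter (a 1.5-fold lower number from compound 2 to compound 3 (0.17 log units; within the scatter)). The comparison of furan-2-yl with the original phenyl group also stays inside the scatter (a 1.7-fold lower number from compound 1 to compound 3 (0.23 log units; within the scatter)), so phenyl, thiophen-3-yl and furan-2-yl cannot be ranked at this position, and the series so far shows no measurable preference among these three aromatic rings. No measurement at hand speaks to why the three numbers sit together.

From the compounds shown here alone, all three groups here are aromatic rings, so it remains open whether an amine, a carboxylic acid or a longer alkyl chain at this position would move the number beyond the scatter. Going by these compounds, the 3-hydroxyphenyl group and the remaining phenyl group are constant throughout, so what a methoxy group in place of the hydroxyl, or a change to that phenyl group, would do also remains open.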